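This account rests on a few compounds, and the source may have more. Where it says the series, first, only, none or still open, it means among the compounds named here.

Working notes on the series. Compound 1 `COc1ccc(-c2cc(/C=C/C(=O)c3ccc(N)cc3)[nH]n2)cc1` gives 2800 nM in a functional assay on HOP-62 cells (Homo sapiens) for inhibition, read by sulforhodamine B assay, with a stated time of 48 h (on this read-out higher numbers stand for weaker inhibition of growth and lower numbers for stronger inhibition of growth), the second highest of the three numbers available. Its nearest neighbour on that read-out is compound 3 `COc1cc(-c2cc(/C=C/C(=O)c3ccc(F)c(F)c3)[nH]n2)cc(OC)c1OC`, which gives 4390 nM, and the furthest is compound 2 `COc1ccc(C(=O)/C=C/c2cc(-c3cc(OC)c(OC)c(OC)c3)n[nH]2)cc1OC`, which gives 1440 nM; both gaps lie within the scatter, so no order among the three can be read from them.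

Going by the values given here, the only single-site step available, a 3.0-fold higher number from compound 2 to compound 3 (0.48 log units; beyond the scatter), concerns the aryl on the carbonyl carbon and not the aryl on the shared core. Compound 4 `COc1ccc(-c2cc(/C=C/C(=O)c3ccc(N)cc3)[nH]n2)cc1OC` differs from compound 1 by methoxy in place of hydrogen on an aromatic carbon, a change on the aryl attached to the core. Among the compounds with values here, no measured pair isolates a methoxy added at that position; compound 2 and compound 3 carry a trimethoxyphenyl there, compound 1 a methoxyphenyl, but those pairs also differ on the carbonyl side, so their values give only a rough sense that the methoxy count on that ring has not moved the read-out far. The expectation in this assay is therefore a step of no more than the scatter, without a clear direction, giving a 1.2-fold lower number from compound 1 to compound 4 (0.09 log units; within the scatter). Compound 4 is accordingly estimated at 2300 nM, within 900 nM to 6000 nM.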

Compound 4, concentration for 50% growth inhibition: 2800 nM
Compound 4: the middle estimate sits 1.2-fold (0.09 log units) below what was measured, within the range that was stated.
By their numbers in this assay, from the lowest: compounds 2, 1, 4 and 3 (each within the scatter of the next, the first and the last beyond it).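

In this assay, going by these compounds alone, methoxy in place of hydrogen on the aromatic carbon ortho to a methoxy group and meta to a large group gives no change at the digits printed from compound 1 to compound 4 (within the scatter) and this is the first pair to isolate that change, which the earlier compounds could approach only through comparisons that also differed on the carbonyl side. With the carbonyl side held fixed, this position takes the added methoxy with no step beyond the scatter, although that finding rests on this single pair. No measurement shown bears on why the read-out holds steady at this position.

From the compounds shown here alone, whether the same holds for a different group on this carbon, such as a hydroxyl, a chlorine atom or the longer ethoxy chain, stays open. Also open, going by these compounds, is whether the methoxy step would read the same with 3,4-difluorophenyl or 3,4-dimethoxyphenyl on the carbonyl carbon in place of the aryl shared by compound 1 and compound 4.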